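This account rests on a few compounds, and the source may have more. Where it says the series, first, only, none or still open, it means among the compounds named here.

- compound 1 `COc1cc(O)c(CC=C(C)C)c(O)c1C(=O)/C=C/c1ccc(Cl)cc1`: 11800 nM
- compound 2 `COc1cc(O)c(CC=C(C)C)c(O)c1C(=O)/C=C/c1ccc([N+](=O)[O-])cc1`: 31200 nM
- compound 3 `COc1cc(O)c(CC=C(C)C)c(O)c1C(=O)/C=C/c1ccc(C(F)(F)F)cc1`: 11100 nM

All three values come from a functional assay on A549 cells (Homo sapiens) for inhibition, read by MTT assay, with a stated time of 72 h; on this read-out higher numbers stand for weaker inhibition and lower numbers for stronger inhibition. Compound 3 sits at the low end of these numbers, but it does not sit there alone. The nearest comparison gives a 1.1-fold lower number from compound 1 to compound 3 (0.03 log units; within the scatter), while the furthest gives a 2.8-fold lower number from compound 2 to compound 3 (0.45 log units; beyond the scatter).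

The next compound is compound 4 `COc1cc(O)cc(O)c1C(=O)/C=C/c1ccc(C(F)(F)F)cc1`, which differs from compound 3 by a single change: hydrogen in place of 3-methylbut-2-en-1-yl on an aromatic carbon. Hydrogen thus stands in place of 3-methylbut-2-en-1-yl on an aromatic carbon, and the rest of the structure stays the same.

Within the data shown here, no measured step touches this place. All three swap one group on the other aromatic ring, so they show only how far the numbers move within this small set. The largest of them are a 2.6-fold higher number from compound 1 to compound 2 (0.42 log units; beyond the scatter) and a 2.8-fold lower number from compound 2 to compound 3 (0.45 log units; beyond the scatter), both modest. Losing a whole chain is a bigger structural change than any of those swaps, so a step of similar modest size is expected, towards a higher number, though the direction rests on no direct evidence.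

The expected step is a 2.7-fold higher number from compound 3 to compound 4 (0.43 log units; beyond the scatter). For compound 4 the estimated value is 30000 nM, with an expected range from 12000 nM to 75000 nM.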

Compound 4, half-maximal inhibitory concentration: 15400 nM
Compound 4: middle estimate off by 1.9-fold (0.29 log units), on the high side; low and high end bracket the measured number.
By their numbers in this assay, from the lowest: compounds 3, 1 and 4 (each within the scatter of the next); then compound 2.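

Replacing the 3-methylbut-2-en-1-yl chain with hydrogen in this assay gives a 1.4-fold higher number from compound 3 to compound 4 (0.14 log units; within the scatter) and leaves compound 4 inseparable from compound 3, so this pair gives no sign that the chain matters to the read-out. The three earlier steps all lay on the other aromatic ring, and two of them went beyond the scatter, whereas this first step at the carbon ortho to two hydroxy groups does not, even though a whole chain of five carbons leaves. No accompanying measurement bears on what lies behind this result.

From the compounds shown here alone, the finding rests on a single pair carrying trifluoromethyl on the other ring, so it remains open whether the same replacement would also stay within the scatter with chloro or nitro there. The compounds shown also leave open what a group other than hydrogen or 3-methylbut-2-en-1-yl would do at this carbon, such as a shorter or longer chain, an amine or a carboxylic acid, and whether any of these would move the number beyond the scatter in either direction.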